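The source may report more compounds than this note shows. Statements on the series, on what has been measured and on what is new or still open speak of the compounds shown alone.

Measured so far, in a functional assay on A549 cells (Homo sapiens) for antiproliferative activity, read by MTT assay, with a stated time of 48 h; a higher number here means a weaker inhibitor, a lower number a stronger inhibitor:
compound 1 `COc1ccc(/C=C/C(=O)Nc2nnc(-c3ccc(Br)cc3)s2)cc1` — 1.04 ug/mL
compound 2 `COc1ccc(/C=C/C(=O)Nc2nnc(-c3ccc(Cl)cc3)s2)cc1` — 1.38 ug/mL
compound 3 `COc1ccc(/C=C/C(=O)Nc2nnc(-c3ccccc3)s2)cc1` — 0.76 ug/mL

Compound 1 gives the second highest of the three numbers in this assay. Its neighbours differ only in the substituent on the aryl group attached to the shared core: a 1.3-fold higher number from compound 1 to compound 2 (0.12 log units; within the scatter), a 1.4-fold lower number from compound 1 to compound 3 (0.14 log units; within the scatter), and a 1.8-fold lower number from compound 2 to compound 3 (0.26 log units; within the scatter). All three steps stay within the scatter, so the three measured compounds cannot be ranked against one another.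

Compound 4 `O=C(/C=C/c1ccc(F)cc1)Nc1nnc(-c2ccc(Br)cc2)s1` has not been measured. Against compound 1 the change is fluoro in place of methoxy on an aromatic carbon. Among the measured compounds shown here, none of the measured steps touches this part of the molecule; they all concern the halogen on the other aromatic ring and all fall within the scatter. There is therefore no measured basis for expecting a step beyond the scatter from compound 1 to compound 4 in this assay, and the estimate for compound 4 is set close to the value of compound 1 with a wide range.

Expected for compound 4 in this assay: 1.2 ug/mL (range 0.5 ug/mL to 3 ug/mL), which is estimated to correspond to a 1.2-fold higher number from compound 1 to compound 4 (0.06 log units; within the scatter).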

Compound 4, half-maximal inhibitory concentration: 2.83 ug/mL
Estimate against measurement, compound 4: 2.4-fold (0.37 log units) below, and the stated range covers the measured number.
By their numbers in this assay, from the lowest: compounds 3, 1 and 2 (each within the scatter of the next); then compound 4.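

In this assay, among the compounds shown here, the change from 4-methoxyphenyl to 4-fluorophenyl gives a 2.7-fold higher number from compound 1 to compound 4 (0.43 log units; beyond the scatter) and is the only step that lies beyond the scatter. The earlier steps all concerned the substituent on the other aromatic ring and stayed within the scatter, so the position that carries methoxy in compound 1 is the only place shown where a single change moves the number measurably. Nothing measured here bears on the reason for this step.

From the compounds shown here alone, only methoxy and fluoro are compared at this position, so it remains open whether a hydroxyl, an amine or a longer ethoxy chain would read closer to compound 1 or to compound 4. Going by these compounds, it also remains open whether the step holds with chloro or hydrogen in place of bromo, as in compound 2 and compound 3.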